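Thioester series: stability toward cocaine esterase

The source may report more compounds than this note shows. Statements on the series, on what has been measured and on what is new or still open speak of the compounds shown alone.

Of the compounds shown here, three have been measured. Compound 1 `CCCCOC(=O)[C@@H](N)CCC(=O)NCCSC(=O)c1ccccc1` gives 0.167 h in an ADME assay on isolated protein for metabolic stability, with Cocaine esterase (Homo sapiens) as the target; on this read-out higher numbers stand for a longer-lived compound and lower numbers for a shorter-lived compound. Compound 2 `CCCCOC(=O)[C@@H](N)CCC(=O)NCCSC(=O)C(C)(C)C` gives 0.167 h in this assay; it carries a tert-butyl on the carbonyl carbon where compound 1 carries a phenyl. Compound 3 `CCCOC(=O)[C@@H](N)CCC(=O)NCCSC(=O)C(C)(C)C` gives 0.167 h in this assay. The step of no change at the digits printed from compound 2 to compound 1 (within the scatter) is the change (phenyl in place of tert-butyl on a carbonyl carbon). The step of no change at the digits printed from compound 2 to compound 3 (within the scatter) is the change (hydrogen in place of methyl on a saturated chain carbon, three bonds along the chain from an oxygen next to a carbonyl group), which is also how the core of compound 3 differs from the core of compound 2. Among the measured compounds shown here, compound 3 stands level with compound 1 and compound 2; no compound among the three stands apart from the others.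

Compound 4 `CCCOC(=O)[C@@H](N)CCC(=O)NCCSC(=O)c1ccccc1` has not been measured. It differs from compound 3 by phenyl in place of tert-butyl on a carbonyl carbon. This is the same change as that from compound 2 to compound 1, and the place is the same in both cases: a carbonyl carbon whose other neighbours are sulfur. Since that earlier change left the half-life unchanged, as no change at the digits printed from compound 2 to compound 1 (within the scatter) shows, the step of no change at the digits printed from compound 3 to compound 4 (within the scatter) is expected to be equally flat. The expectation rests on compound 2 and compound 1 lying level in this assay, and on compound 3 lying level with both. Compound 4 is therefore estimated at 0.167 h in this assay, with a range from 0.08 h to 0.35 h allowing for scatter.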

Compound 4, half-life: 0.167 h
Compound 4: middle estimate and measured number agree at the digits printed; the range from low to high includes it.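

Phenyl in place of tert-butyl on a carbonyl carbon whose other neighbours are sulfur reads the same on both cores in this assay, with no change at the digits printed from compound 3 to compound 4 (within the scatter) standing beside the earlier step on the other core: the same change on two cores in this assay, no change at the digits printed (within the scatter) from compound 2 to compound 1 and no change at the digits printed (within the scatter) from compound 3 to compound 4, 1.0-fold (0.00 log units) apart, within the scatter of two such steps. Hydrogen in place of methyl on a saturated chain carbon, now seen as no change at the digits printed from compound 1 to compound 4 (within the scatter), also reads the same on both cores: the same change on two cores in this assay, no change at the digits printed (within the scatter) from compound 2 to compound 3 and no change at the digits printed (within the scatter) from compound 1 to compound 4, 1.0-fold (0.00 log units) apart, within the scatter of two such steps. This shows that these two changes stay flat across the two cores tested, but all four compounds lie level, so no step beyond the scatter is available to follow from one core to another, and the result says nothing on whether a change that does move the half-life would carry over in this series.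

The compounds shown leave open whether other groups on the carbonyl carbon, such as methyl or a substituted phenyl, or a longer chain on the ester oxygen, would separate from this level set. Also open, going by these compounds, is how a carboxylic acid in place of the ester, or an amide in place of the thioester, would read in this assay.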